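Replacing the indole amide with a cinnamoyl group

A few compounds are considered here, and "the series" means these few. Any claim that something is new, unique, unknown or untested is made for them only; others in the source may bear on it.

Compounds measured so far:
compound 1 `CN1[C@@H]2c3[nH]c4ccccc4c3C[C@H]1[C@H](C#N)N1[C@@H](CNC(=O)c3cccc(C(F)(F)F)c3)c3[nH]c4ccccc4c3C[C@@H]21`, 210 nM
compound 2 `CN1[C@@H]2c3[nH]c4ccccc4c3C[C@H]1[C@H](C#N)N1[C@@H](CNC(=O)c3ccc4ccccc4n3)c3[nH]c4ccccc4c3C[C@@H]21`, 60 nM
compound 3 `CN1[C@@H]2c3[nH]c4ccccc4c3C[C@H]1[C@H](C#N)N1[C@@H](CNC(=O)c3cc4ccccc4[nH]3)c3[nH]c4ccccc4c3C[C@@H]21`, 7100 nM

These three share one core and differ only in the group attached to the amide carbonyl. In a functional assay on A2780 cells (Homo sapiens) for cytotoxicity, read by MTT assay, with a stated time of 72 h (a higher number here means a weaker inhibitor, a lower number a stronger inhibitor), compound 3 gives the highest number of the three, so it is the weakest. Its neighbours show how strongly this position matters: a 34-fold higher number from compound 1 to compound 3 (1.53 log units; beyond the scatter) and a 120-fold higher number from compound 2 to compound 3 (2.07 log units; beyond the scatter), both large and well beyond the scatter.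

Compound 4 `CN1[C@@H]2c3[nH]c4ccccc4c3C[C@H]1[C@H](C#N)N1[C@@H](CNC(=O)/C=C/c3ccccc3)c3[nH]c4ccccc4c3C[C@@H]21` carries the change (2-phenylethenyl in place of 1H-indol-2-yl on a carbonyl carbon). Within the data shown here, no measured step covers this exact group, but both measured steps into compound 3 point the same way: removing the 1H-indol-2-yl group from the carbonyl has, in each case, been paired with a much lower number. A large drop in this assay is therefore expected from compound 3 to compound 4, of about a 24-fold lower number from compound 3 to compound 4 (1.37 log units; beyond the scatter), landing near the other two amides. For compound 4 the expected value is 300 nM, with a range from 70 nM to 2000 nM.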

Compound 4, half-maximal inhibitory concentration: 770 nM
Compound 4: middle estimate off by 2.6-fold (0.41 log units), on the low side; low and high end bracket the measured number.
By their numbers in this assay, from the lowest: compound 2; then compound 1; then compound 4; then compound 3.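

In this assay, a group without the indole ring nitrogen and its hydrogen-bond donor gives a clear improvement, with a 9.2-fold lower number from compound 3 to compound 4 (0.96 log units; beyond the scatter), so the poor result of compound 3 is not shared by every aromatic group at this position. The 2-phenylethenyl group, whose double bond stands outside the aromatic ring, still falls short of both other amides, with a 13-fold higher number from compound 2 to compound 4 (1.11 log units; beyond the scatter) and a 3.7-fold higher number from compound 1 to compound 4 (0.56 log units; beyond the scatter), so the ranking at this carbonyl runs quinolin-2-yl, 3-(trifluoromethyl)phenyl, 2-phenylethenyl, 1H-indol-2-yl. No available evidence accounts for these differences.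

The compounds shown leave open how a 2-phenylethyl group, in which the double bond is gone, would compare with 2-phenylethenyl. They also leave open whether an aromatic ring is needed here at all, a question that a plain butyl chain on the carbonyl would address.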